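Urea series: iodo to methylsulfanyl on the aryl urea

A few compounds are considered here, and "the series" means these few. Any claim that something is new, unique, unknown or untested is made for them only; others in the source may bear on it.

Measured so far:
compound 1, `O=C(Nc1cccc(C(F)(F)F)c1)N[C@H]1CC[C@H](Oc2cccc(F)c2)CC1`, 2400 nM
compound 2, `O=C(Nc1ccc(I)cc1)N[C@H]1CC[C@H](Oc2ccc(F)cc2)CC1`, 10200 nM

In a functional assay on CRL2813 cells (Homo sapiens) for cytotoxicity, read by sulforhodamine B assay, with a stated time of 5 days (a lower number here means a stronger inhibitor, a higher number a weaker inhibitor), compound 2 gives 10200 nM, the highest number of the two; compound 1 gives 2400 nM, a lower number, and the gap between the two lies beyond the scatter. Compound 1 and compound 2 differ in more than one place, so no single step can be read from their two values.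

Compound 3, `CSc1ccc(NC(=O)N[C@H]2CC[C@H](Oc3ccc(F)cc3)CC2)cc1`, has not been measured in this assay. It differs from compound 2 in one place:

methylsulfanyl in place of iodo on an aromatic carbon

The group enters on an aromatic carbon of a six-membered aromatic ring of carbon only, para to a large group. Going by the values given here, no measured pair shows this change, so the size of the step is open. A modest step is expected, most likely not beyond the scatter, with a slight lean toward a lower number: a 1.3-fold lower number from compound 2 to compound 3 (0.11 log units; within the scatter). Compound 3 is therefore estimated at 8000 nM, within 3000 nM to 25000 nM.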

Compound 3, half-maximal inhibitory concentration: > 20000 nM
Compound 3 was reported as a limit; the forecaster's own chance of this, stated with the estimate: 10%; middle value at least 2.5-fold (0.39 log units) away from the limit.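

In this assay compound 3 gives > 20000 nM, a limit of the assay and not a number. Going by these compounds alone, this is the first single-place step: methylsulfanyl in place of iodo on the aromatic carbon gives an at least 1.9-fold higher number from compound 2 to compound 3 (0.29 log units; that floor lies within the scatter), so the exchange brings no gain at this place, while the floor alone does not establish a loss beyond the scatter. The step has a floor but no fixed size, since compound 3 sits at the limit: the limit of > 20000 nM in this assay, at which 1 of the 3 values shown sits.

Going by these compounds, whether another group at this place, such as an amine, a nitrile or a carboxylic acid, would give a lower number than compound 2 remains open. On these data alone, compound 1, at 2400 nM, differs from compound 2 in more than one place, so the steps to it cannot be read, and the source of its lower number is also open.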